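The compounds below may be only part of what the source reports. "The series", "measured", "known", "first", "only" and "open" are said of these compounds alone.

In an ADME assay on HEp-2 cells (Homo sapiens) for cytotoxicity (a lower number here means that less compound is tolerated, a higher number that more compound is tolerated), compound 1 (`CC(C)CCn1c(Cn2c(=O)n(C(C)C)c3ccccc32)nc2cc(CO)ccc21`) gives 31600 nM and compound 2 (`CC(C)CCn1c(Cn2c(=O)n(CC(=O)OC(C)(C)C)c3ccccc32)nc2cc(C#N)ccc21`) gives 32200 nM. These two values lie within the usual scatter of each other, so compound 1 stands level with compound 2. Compound 3 (`CC(C)CCn1c(Cn2c(=O)n(C(C)C)c3ccccc32)nc2cc(C(N)=O)ccc21`) is compound 1 with carbamoyl in place of hydroxymethyl on an aromatic carbon. Compound 1 and compound 2 differ in more than one place, so no measured step sizes this change directly. In this assay, no step beyond the scatter is expected in either direction, and this expectation rests only on compound 1 at 31600 nM and compound 2 at 32200 nM sitting level despite their different substituents. The estimated step is a 1.1-fold lower number from compound 1 to compound 3 (0.02 log units; within the scatter). The expected value for compound 3 is 30000 nM, with an estimated range from 13000 nM to 65000 nM.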

Compound 3, half-maximal cytotoxic concentration: 23400 nM
Beside the measured number, compound 3's estimate is 1.3-fold (0.11 log units) above it, and the stated range covers the measured number.
By their numbers in this assay, from the lowest: compounds 3, 1 and 2 (each within the scatter of the next).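

In this assay, among the compounds shown here, carbamoyl in place of hydroxymethyl on an aromatic carbon gives a 1.4-fold lower number from compound 1 to compound 3 (0.13 log units; within the scatter), and this is the only direct reading of a change at this position, since compound 1 and compound 2 differ in more than one place. With the rest of the core of compound 1 held fixed, the exchange of these two groups, which have the same count of hydrogen-bond donors and acceptors, stays within the scatter. No measurement shown here offers an explanation for this result.

From the compounds shown here alone, whether an amine, a carboxylic acid or a longer chain on this aromatic carbon would also stay level with compound 1 remains open. Also open, going by these compounds, is whether carbamoyl and hydroxymethyl would read alike on a core carrying different groups elsewhere.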